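Shortening the oxime ether chain on a quinone core

The source may hold more compounds than are shown below. What is called first, only, known or untested is meant among the compounds shown, and "the series" means these compounds.

Compound 1, `CCCCCCCCCCCCO/N=C(\CCCCCC)c1cc(OC)c2c(c1OC)C(=O)C=CC2=O`, carries a dodecyl oxime ether and a hexyl ketone-derived oxime; in a functional assay on L1210 cells (Mus musculus) for antiproliferative activity (on this read-out lower numbers stand for an effect already at smaller amounts and higher numbers for an effect only at larger amounts of compound), compound 1 gives 0.193 ug/mL. Its two companions sit close by: compound 2, `CCCCCCCO/N=C/c1cc(OC)c2c(c1OC)C(=O)C=CC2=O`, gives 0.213 ug/mL, and compound 3, `CO/N=C/c1cc(OC)c2c(c1OC)C(=O)C=CC2=O`, gives 0.109 ug/mL, both gaps from compound 1 lying within the usual scatter, so the three numbers are effectively indistinguishable. Compound 4, `CCCCCC/C(=N\OC)c1cc(OC)c2c(c1OC)C(=O)C=CC2=O`, differs from compound 1 by hydrogen in place of undecyl on a saturated chain carbon bound to an oxygen on an unsaturated carbon; cut one bond further out, the same change reads dodecyl to methyl. Within the data shown here, one measured step bears directly on this: a 2.0-fold lower number from compound 2 to compound 3 (0.29 log units; within the scatter), the same kind of chain shortening at the same place, which moved the number only within the scatter. On that basis the shortening in compound 4 is expected to make little difference in this assay, with the estimated step of a 1.4-fold lower number from compound 1 to compound 4 (0.14 log units; within the scatter) not beyond the scatter. Compound 4 is therefore expected to give about 0.14 ug/mL, within a range of 0.06 ug/mL to 0.35 ug/mL.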

Compound 4, concentration for half-maximal effect: 0.192 ug/mL
Beside the measured number, compound 4's estimate is 1.4-fold (0.14 log units) below it; measured number inside the range.
By their numbers in this assay, from the lowest: compounds 3, 4, 1 and 2 (each within the scatter of the next).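

Across a much larger cut than the earlier one, from dodecyl to methyl, the number in this assay shows a 1.0-fold lower number from compound 1 to compound 4 (0.00 log units; within the scatter). The earlier step came from a pair without the hexyl group, so this result adds that the same place accepts the change within the scatter when compounds 1 and 4 share a hexyl ketone-derived oxime. No measurement at hand accounts for this insensitivity to chain length.

The compounds shown leave open whether any group at this place would shift the number beyond the scatter, such as an amine or a carboxylic acid on the chain, or a chain longer than dodecyl. Among these compounds, they also leave open whether the hexyl group itself matters, since no pair here differs in that group alone.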